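Benzofuran acids as free fatty acid receptor 1 agonists

A few compounds are considered here, and "the series" means these few. Any claim that something is new, unique, unknown or untested is made for them only; others in the source may bear on it.

Of the compounds shown here, three have been measured in a functional assay on isolated protein for agonist activity at Free fatty acid receptor 1 (Homo sapiens), read by HTRF and inositol phosphate accumulation, with a stated time of 60 min; a lower number here means that less compound is needed, a higher number that more compound is needed for the effect. Compound 1 `Cc1cc(-c2cc(OC(F)(F)F)ccc2Cl)ccc1OCCCC(=O)O` gives 6720 nM. Compound 2 `O=C(O)CCc1cc2cc(-c3cc(C(=O)C4CC4)ccc3F)ccc2o1` returns only a limit of the assay, > 9950 nM. Going by these compounds, compound 3 `Fc1ccc(OC(F)(F)F)cc1-c1ccc2oc(CCc3nn[nH]n3)cc2c1` likewise returns only a limit, > 9950 nM, so its true value is unknown and it cannot be placed against compound 1 or compound 2 beyond this. The same limit is shared by two of the three values, as noted in the limit of > 9950 nM in this assay, at which 2 of the 3 values shown sit.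

Compound 4 `CC(CC(=O)O)c1cc2cc(-c3cc(OC(F)(F)F)ccc3F)ccc2o1` is the next compound to be tested in this assay. It differs from compound 3 in one place: 1-(carboxymethyl)ethyl in place of 2-(2H-tetrazol-5-yl)ethyl on an aromatic carbon of the fused core. For the measured compounds named here, no measured pair shows this exchange, so its size cannot be read from the data. Compound 2 carries a carboxylic acid chain on the same core and still sits at the limit, which keeps the expectation cautious. The author nevertheless expects compound 4 to come in with a measurable value, an estimated at least 3.9-fold lower number from compound 3 to compound 4 (0.59 log units; beyond the scatter), placing compound 4 at about 2500 nM with a range from 400 nM to 9950 nM.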

Compound 4, half-maximal effective concentration: > 9950 nM
Compound 4 ended at the assay's limit; the forecaster's own chance of this, stated with the estimate: 35%; at least 3.9-fold (0.59 log units) between middle value and limit.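

Compound 3 and compound 4 both end at a limit of the assay rather than at a number, so no step between them can be read: the limit of > 9950 nM in this assay, at which 3 of the 4 values shown sit.

The compounds shown leave open whether 2-(2H-tetrazol-5-yl)ethyl or 1-(carboxymethyl)ethyl on the shared core gives the lower number in this assay, and how large any such difference would be.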